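The source may report more compounds than this note shows. Statements on the series, on what has been measured and on what is new or still open speak of the compounds shown alone.

For the measured compounds named here, compound 1, `CCCCCCN(C)CNCC(=O)[C@H](CC(=O)O)NC(=O)C(CC)n1cc(CC)nc(NCc2nonc2C)c1=O`, is one of two compounds measured so far in a functional assay on NT2 cells (Homo sapiens) for inhibition; a higher number here means a weaker inhibitor, a lower number a stronger inhibitor; in this assay compound 1 gives 0.078 nM. Compound 2, `CCCCCCN(C)CNCC(=O)[C@H](CC(=O)O)NC(=O)C(CC)n1ccnc(NCc2nonc2C)c1=O`, shares the same core and in this assay compound 2 gives 0.13 nM. Going by the values given here, the only change between them is a 1.7-fold higher number from compound 1 to compound 2 (0.22 log units; within the scatter), so the two values lie within the scatter of each other and neither compound can be called the stronger inhibitor on these numbers. Compound 2 thus stands at one of two values that are indistinguishable within the scatter.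

Compound 3, `CCC(C(=O)N[C@H](C=O)CC(=O)O)n1ccnc(NCc2nonc2C)c1=O`, is not yet measured. It differs from compound 2 in one place: hydrogen in place of (((hexyl(methyl)amino)methyl)amino)methyl on a carbonyl carbon. Among the compounds with values here, no measured step involves this part of the molecule; the single step from compound 1 to compound 2 touches an aromatic carbon instead, so it gives no direct guide here. A sizeable piece is removed with nothing put in its place. A weakening is expected rather than a gain, so the estimated step is a 62-fold higher number from compound 2 to compound 3 (1.79 log units; beyond the scatter). For compound 3 in this assay the expected value is 8 nM, with a likely range from 1 nM to 100 nM.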

Compound 3, half-maximal inhibitory concentration: 3.56 nM
Compound 3: the middle estimate sits 2.2-fold (0.35 log units) above what was measured; measured number inside the range.
By their numbers in this assay, from the lowest: compounds 1 and 2 (each within the scatter of the next); then compound 3.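

For the compounds shown here, putting hydrogen in place of (((hexyl(methyl)amino)methyl)amino)methyl on the carbonyl carbon gives a 27-fold higher number from compound 2 to compound 3 (1.44 log units; beyond the scatter) in this assay, whereas the earlier change on an aromatic carbon stayed within the scatter, so this is the first place where a change clearly moves the number. The whole chain is not needed for inhibition, however: without it, compound 3 still gives 3.56 nM, so the part of the molecule that remains inhibits on its own, though more weakly than compound 2. Nothing available explains the size of this step.

Because the chain leaves as one piece, with its 11 heavy atoms, this single step cannot show which part of it matters: the hexyl group, the methyl on the nitrogen, or the two amine nitrogens. A plain methyl on the carbonyl carbon, a butyl in place of the hexyl, or a chain ending in a carboxylic acid would each test a part of the chain, and would show whether the number climbs gradually or only once most of the chain is gone.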